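Amide variation on the shared core and cell tolerance

The source may hold more compounds than are shown below. What is called first, only, known or untested is meant among the compounds shown, and "the series" means these compounds.

Compound 3 `O=C(c1ccccc1Cl)N1CCN(c2nc(=O)c3cc(C(F)(F)F)cc([N+](=O)[O-])c3s2)CC1` stands in an ADME assay on Vero cells (Chlorocebus sabaeus) for cytotoxicity, read by MTT assay, with a stated time of 72 h (a higher number here means that more compound is tolerated, a lower number that less compound is tolerated), only at a limit: compound 3 gives > 125000 nM, a limit rather than a number. Compound 1 `O=C(c1ccc(Cl)cc1)N1CCN(c2nc(=O)c3cc(C(F)(F)F)cc([N+](=O)[O-])c3s2)CC1` sits at that same limit, giving > 125000 nM in this assay. Compound 2 `CC(=O)N1CCN(c2nc(=O)c3cc(C(F)(F)F)cc([N+](=O)[O-])c3s2)CC1` likewise gives > 125000 nM in this assay, again a limit. Going by the values given here, all three values sit at the limit of > 125000 nM in this assay, at which 3 of the 3 values shown sit, so none of the measured steps can be read: a step that the two limits leave unreadable from compound 1 to compound 2, a step that the two limits leave unreadable from compound 1 to compound 3 and a step that the two limits leave unreadable from compound 2 to compound 3 are all of unreadable size.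

Compound 4 `CCCCC(=O)N1CCN(c2nc(=O)c3cc(C(F)(F)F)cc([N+](=O)[O-])c3s2)CC1` has not yet been measured. It differs from compound 3 in one place: butyl in place of 2-chlorophenyl on a carbonyl carbon. Among the compounds with values here, the steps that bear on this are those among compounds 1, 2 and 3, in which the group on the carbonyl carbon went from 4-chlorophenyl to methyl, from 4-chlorophenyl to 2-chlorophenyl and from methyl to 2-chlorophenyl; none of them moved any value off the limit. Aryl and alkyl groups on this carbonyl carbon have so far behaved alike, and no step beyond the scatter is expected for butyl. Compound 4 is expected to give 125000 nM in this assay, within 60000 nM to 300000 nM, most likely again only as a limit. The step of a number no higher from compound 3 to compound 4 (the limit leaves the size open) is thus estimated to be none beyond the scatter.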

Compound 4, half-maximal cytotoxic concentration: > 125000 nM
Compound 4 ended at the assay's limit; the forecaster's own chance of this, stated with the estimate: 85%; the middle value sits exactly at the limit.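

In this assay compound 4 gives > 125000 nM, a limit and not a number. Going by these compounds alone, no step linking compound 4 with compound 1, compound 2 or compound 3 can be read: the limit of > 125000 nM in this assay, at which 4 of the 4 values shown sit.

The compounds shown leave open how far any of the four lies from this limit, and whether any group on the carbonyl carbon gives a readable value.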